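Swapping chloro for bromo in a growth inhibition test

The compounds below may be only part of what the source reports. "The series", "measured", "known", "first", "only" and "open" are said of these compounds alone.

Measured compounds:
compound 1 `O=C(CCCCC(S)CCS)Nc1ccccn1` gives 2.31%
compound 2 `O=C(CCCCC(S)CCS)Nc1ccc(Cl)cn1` gives "not active" (no number reported)

Both compounds were tested in a functional assay on NCI-H460 cells (Homo sapiens) for inhibition, read by MTT assay, with a stated time of 24 h, tested at 1 ug/mL; a lower number here means less inhibition of growth, a higher number more inhibition of growth at the concentration tested. Compound 2 has no single number: it is reported only as "not active" (no number reported). The one figure available nearby is the small reading of compound 1 at 2.31%.

Compound 3 `O=C(CCCCC(S)CCS)Nc1ccc(Br)cn1` has not been measured yet. One place in the structure changes: bromo in place of chloro on an aromatic carbon. For the measured compounds named here, no measured pair shows what such a swap does in this assay, so the expectation is no step beyond the usual scatter, in either direction. That expectation rests only on compound 2 at "not active" (no number reported) and compound 1 at 2.31%. Compound 3 may also be reported without a number. For compound 3 the estimated value is 4%, with an expected range of 0% to 15%.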

Compound 3, percent growth inhibition at one concentration: 10.7%
Estimate against measurement, compound 3: 6.7 percentage points below; measured number inside the range.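

Compound 3 gives a number for a halogen at this position, two atoms from the ring nitrogen, whereas compound 2, with chloro there, is reported only as "not active". In this assay the data show a number 8.4 percentage points higher from compound 1 to compound 3 (within the scatter) when bromo stands in place of hydrogen on an aromatic carbon, so adding bromo here gives no change that can be separated from the usual scatter. Compound 2 has no number, so the step from chloro to bromo cannot be read, and no further measurement helps to explain the result.

On these data alone, it remains open whether another group at this position, such as an amine or a carboxylic acid, would give a reading clearly apart from compound 1. Also open, as far as these compounds go, is what a longer chain in place of the shared chain would do.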